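A few compounds are considered here, and "the series" means these few. Any claim that something is new, unique, unknown or untested is made for them only; others in the source may bear on it.

For the measured compounds named here, in a functional assay on A549 cells (Homo sapiens) for antiproliferative activity, read by MTT assay, with a stated time of 24 h (on this read-out higher numbers stand for weaker inhibition and lower numbers for stronger inhibition), compound 1 `Cc1ccc(C)c(S(=O)(=O)n2c(-c3cn(-c4ccccc4)nc3-c3ccc(F)cc3)nc3ccccc32)c1` gives 200 nM, the lowest of the three numbers measured so far. Compound 2 `O=S(=O)(c1ccc(Cl)cc1)n1c(-c2cn(-c3ccccc3)nc2-c2ccc(F)cc2)nc2ccccc21` gives 3170 nM, and compound 3 `O=S(=O)(c1ccc(C(F)(F)F)cc1)n1c(-c2cn(-c3ccccc3)nc2-c2ccc(F)cc2)nc2ccccc21` gives 1280 nM. Compound 4 `Cc1ccc(C)c(S(=O)(=O)n2c(-c3cn(-c4ccccc4)nc3-c3ccc(C(F)(F)F)cc3)nc3ccccc32)c1`, not yet measured, keeps the sulfonyl group of compound 1 but carries trifluoromethyl in place of fluoro on an aromatic carbon. Going by the values given here, no measured step changes that place, so the evidence is indirect. Changing the group on the sulfonyl sulfur gave a 16-fold higher number from compound 1 to compound 2 (1.20 log units; beyond the scatter) and a 6.4-fold higher number from compound 1 to compound 3 (0.81 log units; beyond the scatter), while trifluoromethyl in place of chloro gave a 2.5-fold lower number from compound 2 to compound 3 (0.39 log units; beyond the scatter). A modest rise is therefore expected in this assay, with real uncertainty about its direction. The estimated change is a 2.3-fold higher number from compound 1 to compound 4 (0.35 log units; beyond the scatter). For compound 4, the estimated value is 450 nM, within an expected range from 130 nM to 1500 nM.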

Compound 4, half-maximal inhibitory concentration: 150 nM
Estimate against measurement, compound 4: 3.0-fold (0.48 log units) above; low and high end bracket the measured number.
By their numbers in this assay, from the lowest: compounds 4 and 1 (each within the scatter of the next); then compound 3; then compound 2.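

In this assay, for the compounds shown here, this is the first direct test of this position: 4-(trifluoromethyl)phenyl in place of 4-fluorophenyl gives a 1.3-fold lower number from compound 1 to compound 4 (0.12 log units; within the scatter). Here, four heavy atoms replace one without moving the number beyond the scatter, unlike the listed changes on the sulfonyl sulfur. No data shown explain this result. Still open, as far as these compounds go, is whether an amine, a carboxylic acid or a methoxy group at this position would keep the number in this range. Also open, from the compounds shown here alone, is whether this swap gives a similar result with the sulfonyl groups of compound 2 or compound 3.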